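Dichlorophenyl to fluoro-trifluoromethylphenyl swap on the bromo core

The source may hold more compounds than are shown below. What is called first, only, known or untested is meant among the compounds shown, and "the series" means these compounds.

Measured so far, in a functional assay on MCF7 cells (Homo sapiens); a higher number here means a weaker inhibitor of growth, a lower number a stronger inhibitor of growth:
- compound 1 `O=S(=O)(/C=C/c1ccc(Cl)cc1Cl)Cc1ccc(Nc2ncnc3ccccc23)cc1`: 4000 nM
- compound 2 `O=S(=O)(/C=C/c1ccc(C(F)(F)F)cc1F)Cc1ccc(Nc2ncnc3ccccc23)cc1`: 100000 nM
- compound 3 `O=S(=O)(/C=C/c1ccc(Cl)cc1Cl)Cc1ccc(Nc2ncnc3ccc(Br)cc23)cc1`: 4000 nM

Compound 3 differs from compound 1 only in the core, by bromo in place of hydrogen on an aromatic carbon; in this assay that gives no change at the digits printed from compound 1 to compound 3 (within the scatter), so the two cores behave alike on the shown pair.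

Compound 4 `O=S(=O)(/C=C/c1ccc(C(F)(F)F)cc1F)Cc1ccc(Nc2ncnc3ccc(Br)cc23)cc1` is not yet measured. It differs from compound 3 by 2-fluoro-4-(trifluoromethyl)phenyl in place of 2,4-dichlorophenyl on a double-bonded chain carbon bound to a double-bonded chain carbon. The same change has been made once before, from compound 1 to compound 2, as 2-fluoro-4-(trifluoromethyl)phenyl in place of 2,4-dichlorophenyl on a double-bonded chain carbon bound to a double-bonded chain carbon; the two place descriptions are identical, so it is the same change. There it gave a 25-fold higher number from compound 1 to compound 2 (1.40 log units; beyond the scatter).

Among the compounds with values here, with the bromo core behaving like the unsubstituted core on the one pair where both are measured, the step from compound 3 to compound 4 in this assay is expected to be about a 25-fold higher number from compound 3 to compound 4 (1.40 log units; beyond the scatter), resting on compound 1 to compound 2 giving a 25-fold higher number from compound 1 to compound 2 (1.40 log units; beyond the scatter) and on compound 3 sitting at 4000 nM. Compound 4 is therefore estimated at 100000 nM, between 30000 nM and 300000 nM.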

Compound 4, concentration for 50% growth inhibition: 32000 nM
Beside the measured number, compound 4's estimate is 3.1-fold (0.49 log units) above it, within the range that was stated.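

In this assay, 2-fluoro-4-(trifluoromethyl)phenyl in place of 2,4-dichlorophenyl gives a higher number on the bromo core too, with an 8.0-fold higher number from compound 3 to compound 4 (0.90 log units; beyond the scatter), so the direction of the change carries from one core to the other, but its size does not: the same change on two cores in this assay, a 25-fold higher number (1.40 log units; beyond the scatter) from compound 1 to compound 2 and an 8.0-fold higher number (0.90 log units; beyond the scatter) from compound 3 to compound 4, 3.1-fold (0.49 log units) apart, beyond the scatter of two such steps

Read the other way round, bromo in place of hydrogen leaves the 2,4-dichlorophenyl pair unchanged but gives a 3.1-fold lower number from compound 2 to compound 4 (0.49 log units; beyond the scatter) on the 2-fluoro-4-(trifluoromethyl)phenyl pair, so the two changes are not independent in this small set: the same change on two cores in this assay, no change at the digits printed (within the scatter) from compound 1 to compound 3 and a 3.1-fold lower number (0.49 log units; beyond the scatter) from compound 2 to compound 4, 3.1-fold (0.49 log units) apart, beyond the scatter of two such steps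

This is a single square of four compounds: it shows that the step size depends on the core, but it does not show what lies behind that dependence, nor what size the step would take on any further core.

The compounds shown leave open whether the smaller step belongs to bromo specifically or would recur with chloro or methoxy on the same aromatic carbon. They also leave open whether the same dependence appears when the aryl group carries a nitrile.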